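The compounds below may be only part of what the source reports. "The series", "measured", "known", "first", "only" and "open" are said of these compounds alone.

Measured compounds:
- Compound 1, `Cc1cc(C)c(Oc2cc(Nc3ccc(C#N)cc3)ncc2C(=O)NCc2cn(Cc3cccc(Cl)c3)nn2)c(C)c1`: in an ADME assay on MT4 cells (Homo sapiens) for cytotoxicity, read by MTT assay, with a stated time of 5 days (a higher number here means that more compound is tolerated, a lower number that less compound is tolerated), compound 1 gives 187000 nM.
- Compound 2, `Cc1cc(C)c(Oc2cc(Nc3ccc(C#N)cc3)ncc2C(=O)NCc2cn(Cc3cccc([N+](=O)[O-])c3)nn2)c(C)c1`: in this assay compound 2 gives >= 156000 nM, which is a limit of the assay and not a number.
- Compound 3, `Cc1cc(C)c(Oc2cc(Nc3ccc(C#N)cc3)ncc2C(=O)NCc2cn(CCC#N)nn2)c(C)c1`: in this assay compound 3 gives 40200 nM.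

Compound 1 holds the highest of the two numbers; the nearest number is that of compound 3, a 4.7-fold lower number from compound 1 to compound 3 (0.67 log units; beyond the scatter), and the remaining value is a limit (the limit of >= 156000 nM in this assay, at which 1 of the 3 values shown sits). The step to compound 4, `Cc1cc(C)c(Oc2cc(Nc3ccc(C#N)cc3)ncc2C(=O)NCc2cn(Cc3ccccc3C)nn2)c(C)c1`, is 2-methylphenyl in place of 3-chlorophenyl on a saturated chain carbon bound to an aromatic nitrogen. Going by the values given here, the only measured step of the same kind, a change on the phenyl of that benzyl group, is a step that the limit leaves unreadable from compound 1 to compound 2, which cannot be read because compound 2 sits at a limit. The steps of a 4.7-fold lower number from compound 1 to compound 3 (0.67 log units; beyond the scatter) and an at least 3.8-fold lower number from compound 2 to compound 3 (0.58 log units; beyond the scatter) remove the phenyl altogether and are of another kind. For compound 4 the expectation is therefore a 1.1-fold lower number from compound 1 to compound 4 (0.04 log units; within the scatter), with no change beyond the scatter. The estimated value for compound 4 in this assay is 170000 nM, between 85000 nM and 340000 nM.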

Compound 4, half-maximal cytotoxic concentration: >= 164000 nM
Compound 4 ended at the assay's limit (the forecaster's own chance of this, stated with the estimate: 30%); the middle value does not contradict the limit.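

In this assay compound 4 ends at a limit and not at a number: the limit of >= 164000 nM in this assay, at which 1 of the 4 values shown sits.

Even so, the change from cyanomethyl to 2-methylphenyl at this saturated chain carbon bound to an aromatic nitrogen reads as an at least 4.0-fold higher number from compound 3 to compound 4 (0.61 log units; beyond the scatter), so a third phenyl-bearing group joins 3-chlorophenyl and 3-nitrophenyl in standing clear of cyanomethyl, and no compound shown goes against this. The steps from compound 1 and from compound 2 to compound 4 cannot be read, so the series gives no size for a change among these phenyl groups.

Open, on these data alone, is whether a longer plain alkyl chain or a chain ending in an amine at this carbon would sit with cyanomethyl or with the phenyl-bearing groups. Also open, as far as these compounds go, is where a carboxylic acid on the phenyl would fall.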